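Replacing the ethylphenyl on the sulfonamide nitrogen

The source may hold more compounds than are shown below. What is called first, only, known or untested is meant among the compounds shown, and "the series" means these compounds.

In a functional assay on CHO cells for antagonist activity at prostaglandin E2 receptor EP1 subtype (Homo sapiens), read by FLIPR and calcium flux (a lower number here means a stronger inhibitor, a higher number a weaker inhibitor), compound 2 `CCc1ccccc1N(Cc1nnc(Cc2ccc(OC)cc2)o1)S(=O)(=O)c1ccc(C)cc1` gives 631 nM, the highest of the three numbers shown. Compound 1 `CCc1ccccc1N(Cc1nnc(Cc2ccc(Cl)cc2)o1)S(=O)(=O)c1ccc(C)cc1` gives 316 nM, and the step of a 2.0-fold higher number from compound 1 to compound 2 (0.30 log units; within the scatter) lies within the scatter. Compound 3 `CCOc1ccc(Cc2nnc(CN(c3ccccc3CC)S(=O)(=O)c3ccc(C)cc3)o2)cc1` gives 39.8 nM, and the step of a 16-fold lower number from compound 2 to compound 3 (1.20 log units; beyond the scatter) is beyond it, as is a 7.9-fold lower number from compound 1 to compound 3 (0.90 log units; beyond the scatter). Compound 4 `COc1ccc(Cc2nnc(CN(c3cccc(Cl)c3Cl)S(=O)(=O)c3ccc(C)cc3)o2)cc1` differs from compound 2 by 2,3-dichlorophenyl in place of 2-ethylphenyl on a sulfonamide nitrogen. Within the data shown here, every measured step alters the group on the benzyl ring, none touches the aryl on the sulfonamide nitrogen, so no measured step bears on this change. Compound 4 is therefore expected to stay near compound 2, with a step of a 1.0-fold lower number from compound 2 to compound 4 (0.00 log units; within the scatter) not beyond the scatter. The estimate for compound 4 is 630 nM, from 130 nM to 3200 nM.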

Compound 4, inhibition constant: 39.8 nM
Compound 4: the middle estimate sits 16-fold (1.20 log units) above what was measured; the measured number lies below the stated range.
By their numbers in this assay, from the lowest: compounds 3 and 4 (each within the scatter of the next); then compounds 1 and 2 (each within the scatter of the next).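

The aryl on the sulfonamide nitrogen proves to be a position that counts: in this assay, the change gives a 16-fold lower number from compound 2 to compound 4 (1.20 log units; beyond the scatter), a large step beyond the scatter. The 2-ethylphenyl and the 2,3-dichlorophenyl each have 8 heavy atoms and no hydrogen-bond donors or acceptors, so those counts do not separate the two groups. Nothing measured here gives a reason for this step.

Going by these compounds, it remains open whether the 2,3-dichlorophenyl gives a similar step with ethoxy or chloro on the benzyl ring. On these data alone, how an amine or a carboxylic acid on this aryl would read also remains open.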